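This account rests on a few compounds, and the source may have more. Where it says the series, first, only, none or still open, it means among the compounds named here.

Compound 1 `CN(C)CC[C@H](CSc1ccccc1)Nc1ccc(S(=O)(=O)NC(=O)c2ccc(N3CCN(Cc4ccccc4-c4ccc(Cl)cc4)CC3)cc2)cc1C(F)(F)F` in an assay on isolated protein for displacement of a labelled ligand from Apoptosis regulator Bcl-2 (Homo sapiens), read by fluorescence polarization (on this read-out higher numbers stand for weaker inhibition and lower numbers for stronger inhibition), gives < 1 nM, a limit of the assay.
Compound 2 `CN(C)CC[C@H](CSc1ccccc1)Nc1ccc(S(=O)(=O)NC(=O)c2ccc(N3CCN(CC4=C(c5ccc(Cl)cc5)CCC4)CC3)cc2)cc1[N+](=O)[O-]` in this assay gives < 1 nM, a limit of the assay.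
Compound 3 `CN(C)CC[C@H](CSc1ccccc1)Nc1ccc(S(=O)(=O)NC(=O)c2ccc(N3CCN(Cc4ccccc4-c4ccc(Cl)cc4)CC3)cc2)cc1` in this assay gives < 1 nM, a limit of the assay.

For the measured compounds named here, compound 1 thus stands only at a limit; all three values sit at the limit of < 1 nM in this assay, at which 3 of the 3 values shown sit, so no compound can be ordered against another. Going by the values given here, the one step at the same aromatic carbon, a step that the two limits leave unreadable from compound 1 to compound 3, is unreadable for that reason.

Compound 4 `CN(C)CC[C@H](CSc1ccccc1)Nc1ccc(S(=O)(=O)NC(=O)c2ccc(N3CCN(Cc4ccccc4-c4ccc(Cl)cc4)CC3)cc2)cc1S(=O)(=O)C(F)(F)F` differs from compound 1 by (trifluoromethyl)sulfonyl in place of trifluoromethyl on an aromatic carbon. Among the compounds with values here, no measured step gives a readable size for this position, and nothing points in either direction. Compound 4 is therefore expected to remain at or near the limit, with an estimate of 0.7 nM (range 0.1 nM to 5 nM), a step that the limit leaves unreadable from compound 1 to compound 4 expected to lie within the scatter.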

Compound 4, inhibition constant: < 1 nM
Compound 4 ended at the assay's limit; the forecaster's own chance of this, stated with the estimate: 65%; the middle value is on the limit's open side.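

Neither the step from compound 1 to compound 4 nor the step from compound 3 to compound 4 can be read, as compound 4 also stands at a limit: the limit of < 1 nM in this assay, at which 4 of the 4 values shown sit.

On these data alone, whether trifluoromethyl, hydrogen and (trifluoromethyl)sulfonyl differ at all in this assay stays open.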